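This account rests on a few compounds, and the source may have more. Where it says the series, first, only, none or still open, it means among the compounds named here.

Measured compounds:
compound 1 `Cc1oc(-c2ccc(Cl)cc2)nc1CN1CCC(C(=O)NCCCN2C[C@H](C)C[C@H](C)C2)CC1` — 11500 nM
compound 2 `Cc1ccccc1-c1nc(CN2CCC(C(=O)NCCCN3CCC(C)CC3)CC2)c(C)o1` — 12300 nM

In an ADME assay on Huh7.5.1 cells (Homo sapiens) for cytotoxicity, read by ATP content, with a stated time of 48 h (on this read-out lower numbers stand for higher toxicity in this test and higher numbers for lower toxicity in this test), compound 1 gives 11500 nM and compound 2 gives 12300 nM. Compound 1 holds the lowest of the two numbers, yet its nearest neighbour, compound 2, lies within the scatter of it, so the two cannot be told apart.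

Compound 3 `COc1cccc(C)c1-c1nc(CN2CCC(C(=O)NCCCN3C[C@H](C)C[C@H](C)C3)CC2)c(C)o1` follows from compound 1 by one change: 2-methoxy-6-methylphenyl in place of 4-chlorophenyl on an aromatic carbon. Among the compounds with values here, no measured pair shows a step of this kind, and the two measured numbers sit within the scatter of each other, so for this assay no shift beyond the scatter is expected in either direction. Compound 3 is expected at 12000 nM, between 6000 nM and 25000 nM. The expected step is a 1.0-fold higher number from compound 1 to compound 3 (0.02 log units; within the scatter).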

Compound 3, half-maximal cytotoxic concentration: 16700 nM
Beside the measured number, compound 3's estimate is 1.4-fold (0.14 log units) below it, and the stated range covers the measured number.
By their numbers in this assay, from the lowest: compounds 1, 2 and 3 (each within the scatter of the next).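

In this assay, within the data shown here, 2-methoxy-6-methylphenyl in place of 4-chlorophenyl gives a 1.5-fold higher number from compound 1 to compound 3 (0.16 log units; within the scatter), the first one-place comparison. At this aromatic carbon of the five-membered ring, the chlorine can thus give way to a methoxy and a methyl group without a shift beyond the scatter. No available measurement bears on this result. Going by these compounds, the separate contributions of the methoxy and methyl groups remain open. Also open, on these data alone, is whether a carboxylic acid or an amine on the phenyl ring, or cyclohexyl in its place, would move the number beyond the scatter.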